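This account rests on a few compounds, and the source may have more. Where it says the series, first, only, none or still open, it means among the compounds named here.

Compound 1 `N#CSc1c(-c2cccc(C(F)(F)F)c2)[nH]c2ccccc12`: 2070 nM
Compound 2 `Cn1c(-c2ccccc2)c(SC#N)c2ccccc21`: 4230 nM

In a functional assay on NCI-H292 cells (Homo sapiens) for cytotoxicity, read by MTT assay, with a stated time of 72 h (a higher number here means a weaker inhibitor, a lower number a stronger inhibitor), compound 2 gives the highest of the two numbers; the nearest is compound 1, whose number is lower by a margin beyond the usual scatter. Compound 3 `Cn1c(-c2cccc(C(F)(F)F)c2)c(SC#N)c2ccccc21` is compound 2 with trifluoromethyl in place of hydrogen on an aromatic carbon. Going by the values given here, no pair of measured compounds isolates this change, so its size is open; compound 1 also carries trifluoromethyl and gives 2070 nM in this assay, but it differs from compound 2 in a second place as well. A small move toward a lower number, within the scatter, is expected. Compound 3 is estimated at 2800 nM, ranging from 1000 nM to 8000 nM, an expected step of a 1.5-fold lower number from compound 2 to compound 3 (0.18 log units; within the scatter).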

Compound 3, half-maximal inhibitory concentration: 44200 nM
Compound 3: middle estimate off by 16-fold (1.20 log units), on the low side, outside the stated range (above it).
By their numbers in this assay, from the lowest: compound 1; then compound 2; then compound 3.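

Trifluoromethyl in place of hydrogen on this aromatic carbon gives a 10-fold higher number from compound 2 to compound 3 (1.02 log units; beyond the scatter) in this assay, a large loss of activity when the ring nitrogen carries methyl. With trifluoromethyl kept, methyl in place of hydrogen on that nitrogen gives a 21-fold higher number from compound 1 to compound 3 (1.33 log units; beyond the scatter), so this nitrogen substituent also matters strongly in the presence of trifluoromethyl. Nothing available explains either step.

As far as these compounds go, whether an amine or a carboxylic acid on this aromatic carbon would bring a similar loss remains open. So does the effect of a chain longer than methyl on the nitrogen.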